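The compounds below may be only part of what the source reports. "The series", "measured", "known", "first", "only" and "open" are said of these compounds alone.

Of the compounds shown here, two of a shared core have been measured in a functional assay on the whole organism (strain Swiss albino) for inhibition, with Mus musculus as the target, in the writhing test, with stated times of 60 min and 15 min, at a dose of 100 mg/kg by the oral route; on this read-out lower numbers stand for less inhibition and higher numbers for more inhibition at the one dose given (going by the name of the read-out). Compound 1, `CCN(CC)C(=O)CC1CCc2cc(OC)c(OC)cc21`, gives 27.4% in this assay. Compound 2, `CCCCCCNC(=O)CC1CCc2cc(OC)c(OC)cc21`, gives 82.2% in this assay, which is the higher of the two numbers. Among the measured compounds shown here, the single step between them, a number 54.8 percentage points higher from compound 1 to compound 2 (beyond the scatter), is the only comparison that has been measured so far, and it shows that exchanging the group on the carbonyl carbon moves the read-out by a large amount.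

Compound 3, `COc1cc2c(cc1OC)C(CC(=O)N1CCOCC1)CC2`, is the next member of the series. It differs from compound 2 in one place: morpholin-4-yl in place of hexylamino on a carbonyl carbon. The step from compound 1 to compound 2 bears on this change, since it too alters the group on the carbonyl carbon, and it was large. Compound 3 returns to a group without a hydrogen-bond donor on that carbonyl carbon, as in compound 1, so a step back toward the number of compound 1 is expected, with a drop in this assay given by a number 47.2 percentage points lower from compound 2 to compound 3 (beyond the scatter). The estimate for compound 3 in this assay is therefore 35%, within a range from 15% to 60%.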

Compound 3, a percentage reported as inhibition, in the whole organism at one dose (the size of the read-out at that dose, not a potency): 23.6%
For compound 3 the middle estimate is 11.4 percentage points above the measured one; the range from low to high includes it.
By their numbers in this assay, from the lowest: compounds 3 and 1 (each within the scatter of the next); then compound 2.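

In this assay, morpholin-4-yl in place of hexylamino on a carbonyl carbon gives a number 58.6 percentage points lower from compound 2 to compound 3 (beyond the scatter), so the high number of compound 2 does not carry over to this ring-bearing group at this position. Morpholin-4-yl in place of diethylamino gives a number 3.8 percentage points lower from compound 1 to compound 3 (within the scatter), so at this position, replacing the open diethylamino group with the morpholine ring and its oxygen leaves the read-out unresolved from that of compound 1, and among these three compounds only hexylamino, the one group here that keeps the amide hydrogen, stands apart from the other two. No evidence at hand accounts for the gap between hexylamino and the other two groups.

Hexylamino differs from morpholin-4-yl in both its open chain and its hydrogen-bond donor, so these compounds leave open which of the two goes with the high number of compound 2. Butylamino or octylamino would speak to the length of the chain, N-methylhexylamino to the amide hydrogen with the chain kept, and piperidin-1-yl to the ring without its oxygen.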